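This account rests on a few compounds, and the source may have more. Where it says the series, first, only, none or still open, it means among the compounds named here.

Measured in a functional assay on A549 cells (Homo sapiens) for antiproliferative activity, read by WST assay, with a stated time of 120 h; a higher number here means a weaker inhibitor, a lower number a stronger inhibitor:
- Compound 1 `CCC[C@H]1C[C@@H](OC)C/C(C)=C\[C@@H]2C[C@@H](OC(=O)/C=C\CCc3coc(/C=C\CNC(=O)OC)n3)C[C@H](CC(=O)O1)O2`: 0.5 nM
- Compound 2 `CCC[C@H]1C[C@@H](OC)C/C(C)=C\[C@@H]2C[C@@H](OC(=O)/C=C\CCc3coc(C=C(C)C)n3)C[C@H](CC(=O)O1)O2`: 3900 nM

Of these two compounds, compound 2 has the higher number, which marks it as the weaker inhibitor. Within the data shown here, only one measured step is available, a 7800-fold higher number from compound 1 to compound 2 (3.89 log units; beyond the scatter). It is large and lies well beyond the scatter. In that step, 2-methylprop-1-en-1-yl takes the place of 3-((methoxycarbonyl)amino)prop-1-en-1-yl on an aromatic carbon.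

Compound 3 `CCC[C@H]1C[C@@H](OC)C/C(C)=C\[C@@H]2C[C@@H](OC(=O)/C=C\CCc3coc(CCCNC(=O)OC)n3)C[C@H](CC(=O)O1)O2` has 3-((methoxycarbonyl)amino)propyl in place of 2-methylprop-1-en-1-yl on that same carbon: 3-((methoxycarbonyl)amino)propyl in place of 2-methylprop-1-en-1-yl on an aromatic carbon. This brings back the carbamate end seen in compound 1, but on a propyl chain rather than a prop-1-en-1-yl chain. Among the measured compounds shown here, that makes the measured step the only guide, read in reverse. For the measured compounds named here, no measured compound carries the propyl chain, so a full return to the level of compound 1 cannot be assumed.

A large drop in this assay is therefore expected, stopping short of that level. The expected change is a 260-fold lower number from compound 2 to compound 3 (2.41 log units; beyond the scatter). For compound 3 the estimated value is 15 nM, with an expected range of 1 nM to 300 nM.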

Compound 3, half-maximal inhibitory concentration: 400 nM
For compound 3 the middle estimate is 27-fold (1.43 log units) below the measured one; measured number above the stated range.
By their numbers in this assay, from the lowest: compound 1; then compound 3; then compound 2.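

Compound 3 shows that the carbamate end does not work on its own at this position on the ring. In this assay, adding it on a propyl chain gives only a 9.8-fold lower number from compound 2 to compound 3 (0.99 log units; beyond the scatter), a modest gain that is still beyond the scatter. The chain that carries the carbamate turns out to matter more: with the same end group in both compounds, replacing prop-1-en-1-yl with propyl gives an 800-fold higher number from compound 1 to compound 3 (2.90 log units; beyond the scatter), and this large step accounts for most of the gap between compound 1 and compound 2. Nothing available here explains why the saturated chain gives so much weaker an inhibitor.

The compounds shown cannot separate the effect of the chain from that of the end group, since only one end group appears on each of these two chains, so it remains open whether a free amine or an acetamide on the prop-1-en-1-yl chain would stay close to compound 1. Also open, on these data alone, is how a longer chain, such as butyl carrying the same carbamate, would compare with the propyl chain of compound 3.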